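The compounds below may be only part of what the source reports. "The series", "measured", "known", "first", "only" and "open" are said of these compounds alone.

Going by the values given here, in a functional assay on MOLT-4 cells (Homo sapiens) for antiproliferative activity (a lower number here means a stronger inhibitor, a higher number a weaker inhibitor), compound 3 (`COc1cc(C(=O)c2sc(-c3ccccc3)cc2N)cc(OC)c1OC`) gives 5.3 nM as the lowest of the three numbers so far, and its steps to both others lie beyond the scatter. Compound 1 (`COc1cc(C(=O)c2sc(-c3ccc([N+](=O)[O-])cc3)cc2N)cc(OC)c1OC`) gives 110 nM and compound 2 (`COc1cc(C(=O)c2sc(-c3ccc(I)cc3)cc2N)cc(OC)c1OC`) gives 190 nM with no separation beyond the scatter. Compound 4 (`COc1cc(C(=O)c2sc(-c3ccc(Cl)c(Cl)c3)cc2N)cc(OC)c1OC`) is unmeasured and has 3,4-dichlorophenyl in place of phenyl on an aromatic carbon. The nearest evidence is a 21-fold lower number from compound 1 to compound 3 (1.32 log units; beyond the scatter) and a 36-fold lower number from compound 2 to compound 3 (1.55 log units; beyond the scatter) as two large steps. Read in reverse, both show a substituted phenyl with the higher number. Neither compound holds chlorine, so the transfer is uncertain. A large step to a higher number is still expected in this assay here. The expected step is a 19-fold higher number from compound 3 to compound 4 (1.28 log units; beyond the scatter) by this estimate. Compound 4 is estimated at 100 nM with an expected range of 20 nM to 500 nM for now.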

Compound 4, half-maximal inhibitory concentration: 270 nM
For compound 4 the middle estimate is 2.7-fold (0.43 log units) below the measured one; the range from low to high includes it.
By their numbers in this assay, from the lowest: compound 3; then compounds 1, 2 and 4 (each within the scatter of the next, the first and the last beyond it).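

In this assay the phenyl on this aromatic carbon next to the ring sulfur again loses activity once substituted, with a 51-fold higher number from compound 3 to compound 4 (1.71 log units; beyond the scatter) as the largest step, so the loss also holds for a group bearing two chlorines. Among the substituted phenyls, a 1.4-fold higher number from compound 2 to compound 4 (0.15 log units; within the scatter) stays within the scatter, while a 2.5-fold higher number from compound 1 to compound 4 (0.39 log units; beyond the scatter) is only modest and leaves the three compounds close together. Nothing available accounts for these steps. Still open, as far as these compounds go, is whether a methyl, a methoxy or an amino group on the phenyl would keep the low number of compound 3. From the compounds shown here alone, a single chlorine on the phenyl is equally open.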